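This account rests on a few compounds, and the source may have more. Where it says the series, first, only, none or still open, it means among the compounds named here.

Compound 1 `COc1ccc(-c2nc(-c3ccccc3)c(-c3ccc4c(c3)NC(=O)CO4)[nH]2)cc1` gives 19.1% in a functional assay on DLD-1 cells (Homo sapiens) for cytotoxicity, read by colorimetric assay and MTT assay, with a stated time of 3 days, tested at 20 uM; on this read-out lower numbers stand for a stronger effect and higher numbers for a weaker effect at the one concentration tested.
Compound 2 `O=C1COc2ccc(-c3[nH]c(-c4c[nH]c5ncccc45)nc3-c3ccccc3)cc2N1` gives 53.5%.
Compound 3 `O=C1COc2ccc(-c3[nH]c(-c4ccc(F)cc4)nc3-c3ccccc3)cc2N1` gives 29.5%.

Among these three numbers compound 3 stands second highest. Its nearest neighbour is compound 1, with the difference a number 10.4 percentage points higher from compound 1 to compound 3 (beyond the scatter) counted as beyond the scatter; its furthest is compound 2, where the step of a number 24 percentage points lower from compound 2 to compound 3 (beyond the scatter) is also beyond the scatter.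

Compound 4 `O=C1COc2ccc(-c3[nH]c(-c4ccc(Cl)cc4Cl)nc3-c3ccccc3)cc2N1` has not yet been measured. It differs from compound 3 in one place: 2,4-dichlorophenyl in place of 4-fluorophenyl on an aromatic carbon. The two steps already seen bear on this position, since both alter the same aryl group on the shared core: a number 10.4 percentage points higher from compound 1 to compound 3 (beyond the scatter) was modest, and a number 24 percentage points lower from compound 2 to compound 3 (beyond the scatter) was modest as well. Exchanging one six-membered carbon ring for another at this site thus moved the read-out by an amount beyond the scatter in both cases, though in opposite directions, so no direction can be read from them for a change within substituted phenyl groups. A modest step in either direction is expected, with no clear sign. The estimated step is a number 0.5 percentage points higher from compound 3 to compound 4 (within the scatter). Compound 4 is therefore expected to give about 30%, within a range from 12% to 50%.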

Compound 4, a percentage reported as activity, at one concentration (the size of the read-out at that concentration, not a potency): 61.9%
Beside the measured number, compound 4's estimate is 31.9 percentage points below it, and the stated range ends below it.
By their numbers in this assay, from the lowest: compound 1; then compound 3; then compounds 2 and 4 (each within the scatter of the next).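

In this assay, 2,4-dichlorophenyl in place of 4-fluorophenyl on the aromatic carbon between two ring nitrogen atoms gives a number 32.4 percentage points higher from compound 3 to compound 4 (beyond the scatter), a large step towards a weaker effect, so a change that keeps a substituted phenyl group at this position can still move the read-out far. The same group in place of 4-methoxyphenyl gives a number 42.8 percentage points higher from compound 1 to compound 4 (beyond the scatter), also large and in the same direction, which places both compounds with a single substituent on the phenyl group on the stronger side of the 2,4-dichlorophenyl compound. Against the quite different group of compound 2, the result is a number 8.4 percentage points higher from compound 2 to compound 4 (within the scatter), so the two compounds cannot be told apart here, even though one carries a single aromatic ring at this position and the other carries two.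

The data at hand offer no explanation for these steps. Going by these compounds, it also remains open whether the large step follows from the exchange of fluorine for chlorine or from the second chlorine, a question that 4-chlorophenyl would address, and how an amine or a carboxylic acid on the phenyl group would read.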